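The compounds below may be only part of what the source reports. "The series", "measured", "known", "first", "only" and "open" are said of these compounds alone.

In a functional assay on MCF7 cells (Homo sapiens) for cytotoxicity, read by MTT assay, with a stated time of 48 h (a higher number here means a weaker inhibitor, a lower number a stronger inhibitor), three compounds have been measured so far:
compound 1, `O=C(CSc1nnc(-c2ccncc2)o1)N/N=C/c1ccc(F)cc1`, gives 13500 nM;
compound 2, `Cc1ccc(/C=N/NC(=O)CSc2nnc(-c3ccncc3)o2)cc1`, gives 14700 nM;
compound 3, `COc1cccc(/C=N/NC(=O)CSc2nnc(-c3ccncc3)o2)c1`, gives 13800 nM.

Compound 1 holds the lowest of the three numbers, yet the steps of a 1.1-fold higher number from compound 1 to compound 2 (0.04 log units; within the scatter) and a 1.0-fold higher number from compound 1 to compound 3 (0.01 log units; within the scatter) both lie within the scatter, so no order among the three can be claimed. The unmeasured compound 4, `O=C(CSc1nnc(-c2ccncc2)o1)N/N=C/c1ccc(O)c(O)c1`, differs from compound 1 by 3,4-dihydroxyphenyl in place of 4-fluorophenyl on a carbon with a double bond to nitrogen. Both measured steps from compound 1 exchange the group on a carbon with a double bond to nitrogen, and neither moved the number beyond the scatter; the step of a 1.1-fold lower number from compound 2 to compound 3 (0.03 log units; within the scatter) is flat too. Among the measured compounds shown here, no measured step brings in hydroxyl groups, so the bearing is indirect. Compound 4 is therefore expected to show no step beyond the scatter, a 1.1-fold lower number from compound 1 to compound 4 (0.05 log units; within the scatter). Compound 4 is estimated at 12000 nM, with a range from 5000 nM to 30000 nM.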

Compound 4, half-maximal inhibitory concentration: 910 nM
Beside the measured number, compound 4's estimate is 13-fold (1.12 log units) above it, and the stated range ends above it.
By their numbers in this assay, from the lowest: compound 4; then compounds 1, 3 and 2 (each within the scatter of the next).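

In this assay the group on a carbon with a double bond to nitrogen, flat across the earlier exchanges, proves able to move the number strongly: 3,4-dihydroxyphenyl gives a 15-fold lower number from compound 1 to compound 4 (1.17 log units; beyond the scatter) and a 15-fold lower number from compound 3 to compound 4 (1.18 log units; beyond the scatter) and also a 16-fold lower number from compound 2 to compound 4 (1.21 log units; beyond the scatter) in the same series. The earlier flatness therefore held only among 4-fluorophenyl, 4-methylphenyl and 3-methoxyphenyl, none of which carries a hydroxyl group. Nothing measured here explains the change. From the compounds shown here alone, whether a single hydroxyl group would suffice stays open, as does what an amino group or a carboxylic acid would do on that ring.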